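A few compounds are considered here, and "the series" means these few. Any claim that something is new, unique, unknown or untested is made for them only; others in the source may bear on it.

Three compounds built on one shared core have been examined in a toxicity assay on THP-1 cells (Homo sapiens) for cytotoxicity, read by MTT assay; on this read-out higher numbers stand for weaker inhibition of growth and lower numbers for stronger inhibition of growth. Compound 1 `C/C(=N\Nc1nc(-c2ccc(Cl)cc2)cs1)c1sc(C)nc1C` reaches only the limit of the assay, recorded as > 100 ug/mL. Compound 2 `C/C(=N\Nc1nc(-c2ccc(Br)cc2)cs1)c1sc(C)nc1C` also stops at the limit, recorded as > 100 ug/mL. Compound 3 `C/C(=N\Nc1nc(-c2ccc(C)cc2)cs1)c1sc(C)nc1C` likewise stands at the limit, recorded as > 100 ug/mL. Because every one of these values sits at the limit of > 100 ug/mL in this assay, at which 3 of the 3 values shown sit, none of the steps between them can be sized: a step that the two limits leave unreadable from compound 1 to compound 2, a step that the two limits leave unreadable from compound 1 to compound 3 and a step that the two limits leave unreadable from compound 2 to compound 3 each remain unreadable. Compound 3 therefore holds nothing more than a limit in this assay, and no number.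

Compound 4 `COc1ccc(-c2csc(N/N=C(\C)c3sc(C)nc3C)n2)cc1` differs from compound 3 by methoxy in place of methyl on an aromatic carbon. None of the three measured steps shows a change of this kind, and since all three were left unreadable by their limits, they offer no size against which this change could be weighed. What remains is the observation that compound 3 gives only a limit, and so compound 4 is expected to behave in the same way. The step in this assay is estimated as a number no higher from compound 3 to compound 4 (the limit leaves the size open), meaning no movement beyond the scatter. Compound 4 is estimated at 100 ug/mL, within a range from 50 ug/mL to 200 ug/mL, most likely reported once more as a limit rather than as a number.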

Compound 4, concentration for 50% growth inhibition: > 100 ug/mL
Compound 4 ended at the assay's limit (the forecaster's own chance of this, stated with the estimate: 85%); the middle value lies on the limit itself.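

No new step can be read for compound 4 against compound 1, compound 2 or compound 3, because each result in this assay is a limit and not a number: the limit of > 100 ug/mL in this assay, at which 4 of the 4 values shown sit.

The compounds shown leave open how strongly any of the four inhibits growth, and whether the chloro, bromo, methyl and methoxy compounds differ at all.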